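The source may hold more compounds than are shown below. What is called first, only, known or untested is meant among the compounds shown, and "the series" means these compounds.

Measured in a functional assay, read by fluorescence and spectrophotometry, with a stated time of 1 h; on this read-out lower numbers stand for an effect already at smaller amounts and higher numbers for an effect only at larger amounts of compound:
- compound 1 `O=S(=O)(/C=C/c1ccc(O)c(O)c1)CC1CCC1`: 8800 nM
- compound 2 `O=S(=O)(/C=C/c1ccc(O)c(O)c1)CCC1CCCCC1`: 9800 nM
- compound 3 `O=S(=O)(/C=C/c1ccc(O)c(O)c1)CC1CCCN1`: 13800 nM

Compound 3 stands within the scatter of both other compounds: a 1.6-fold higher number from compound 1 to compound 3 (0.20 log units; within the scatter) and a 1.4-fold higher number from compound 2 to compound 3 (0.15 log units; within the scatter). The next compound is compound 4 `O=S(=O)(/C=C/c1ccc(O)c(O)c1)CCCCCCCO`, with this change: 6-hydroxyhexyl in place of pyrrolidin-2-yl on a saturated chain carbon bound to a sulfonyl sulfur. Going by the values given here, no measured compound carries 6-hydroxyhexyl, so no step matches this change directly. The nearest evidence is the three steps among the measured compounds at this place, which also include a 1.1-fold higher number from compound 1 to compound 2 (0.05 log units; within the scatter). All three stay within the scatter, so no step beyond the scatter is expected in this assay. The expected step is a 1.3-fold lower number from compound 3 to compound 4 (0.10 log units; within the scatter). For compound 4 the estimated value is 11000 nM, with an expected range of 5000 nM to 24000 nM.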

Compound 4, half-maximal effective concentration: 5900 nM
Estimate against measurement, compound 4: 1.9-fold (0.27 log units) above; low and high end bracket the measured number.
By their numbers in this assay, from the lowest: compounds 4, 1, 2 and 3 (each within the scatter of the next, the first and the last beyond it).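

In this assay this position gives its first step beyond the scatter, a modest one: a 2.3-fold lower number from compound 3 to compound 4 (0.37 log units; beyond the scatter) with 6-hydroxyhexyl in place of pyrrolidin-2-yl. Against the other two groups the change stays within the scatter, with a 1.7-fold lower number from compound 2 to compound 4 (0.22 log units; within the scatter) and a 1.5-fold lower number from compound 1 to compound 4 (0.17 log units; within the scatter) as the printed steps, so a chain with no ring holds up here alongside the ring-bearing groups. No evidence on the origin of the step is at hand.

Still open, from the compounds shown here alone, is how a plain hexyl chain compares with 6-hydroxyhexyl. Also open, going by these compounds, is whether a longer chain, or a carboxylic acid in place of the hydroxyl, moves the number further.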